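Chloro in place of methyl: notes on the series

The source may hold more compounds than are shown below. What is called first, only, known or untested is meant among the compounds shown, and "the series" means these compounds.

Measured values in a functional assay on MCF7 cells (Homo sapiens) for antiproliferative activity, read by MTT assay, with a stated time of 48 h (a lower number here means a stronger inhibitor, a higher number a weaker inhibitor), are these

- compound 1 `Cc1ccc(/C=C/C(=O)Nc2nnc(-c3ccc(Cl)cc3)s2)cc1` gives 1.44 ug/mL
- compound 2 `Cc1ccc(-c2nnc(NC(=O)/C=C/c3ccc(F)cc3)s2)cc1` gives 1.27 ug/mL

In this assay compound 2 stands at 1.27 ug/mL and lies within the scatter of compound 1, so these two numbers cannot be ranked. Going by the values given here, with only two values on hand, compound 2 marks a level for the series and nothing more.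

Compound 3 `O=C(/C=C/c1ccc(F)cc1)Nc1nnc(-c2ccc(Cl)cc2)s1` has not yet been measured. It differs from compound 2 at one place, with chloro in place of methyl on an aromatic carbon, para to a large group (chloro in place of methyl on an aromatic carbon). The same difference, read one bond further out, is 4-methylphenyl to 4-chlorophenyl.

Among the compounds with values here, no measured pair differs at one place only, so the series offers no direct precedent for this change. Within the data shown here, the only guide is the close agreement of the two values, with compound 1 at 1.44 ug/mL and compound 2 at 1.27 ug/mL in this assay (within the scatter). No step beyond the scatter is therefore expected, in either direction. The expected change is a 1.0-fold higher number from compound 2 to compound 3 (0.01 log units; within the scatter) (an estimate). The estimated value for compound 3 is 1.3 ug/mL (expected range 0.7 ug/mL to 2.4 ug/mL).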

Compound 3, half-maximal inhibitory concentration: 1.58 ug/mL
The estimate for compound 3 lay 1.2-fold (0.08 log units) below the measured number; low and high end bracket the measured number.
By their numbers in this assay, from the lowest: compounds 2, 1 and 3 (each within the scatter of the next).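

In this assay, the series now has its first comparisons that differ in one place only. Chloro in place of methyl on an aromatic carbon, para to a large group, gives a 1.2-fold higher number from compound 2 to compound 3 (0.09 log units; within the scatter), so 4-methylphenyl and 4-chlorophenyl cannot be told apart at this position, and the second comparison that differs in one place gives a 1.1-fold higher number from compound 1 to compound 3 (0.04 log units; within the scatter), which likewise cannot be ranked. Both changes therefore leave the number inside the scatter, but no accompanying measurement offers an account of this result.

Open, on these data alone, is whether any group at this position moves the number beyond the scatter, since methyl and chloro are the only two compared there and neither separates from the other. An amine, a carboxylic acid or a methoxy group on the same aromatic carbon would test whether this tolerance extends beyond these small substituents, or whether the flat reading seen so far belongs to methyl and chloro alone.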